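Cytotoxicity notes on compounds 1 to 4

A few compounds are considered here, and "the series" means these few. Any claim that something is new, unique, unknown or untested is made for them only; others in the source may bear on it.

Compound 1 `Cc1ccc(C(=O)Nc2ncc(Cc3ccc(F)cc3)s2)cc1` and compound 2 `O=C(Nc1ncc(Cc2ccc(Cl)cc2)s1)c1ccc(F)cc1F` are the two amide members of the set; in an ADME assay on HepG2 2.2.15 cells (Homo sapiens) for cytotoxicity (a higher number here means that more compound is tolerated, a lower number that less compound is tolerated), compound 1 is recorded as "not toxic" (no number reported), and compound 2 in this assay as "not toxic" (no number reported), neither with a number attached. For the measured compounds named here, compound 3 `Cc1cc(C(C)C)ccc1OC(c1ccc(Cl)cc1)c1cnc(NC(=O)OC(C)(C)C)s1` is the only member with a reported figure, and that figure is a limit of the assay rather than a measured number: in this assay compound 3 gives > 50000 nM. Going by the values given here, compound 3 therefore stands at the limit of > 50000 nM in this assay, at which 1 of the 3 values shown sits, with the other two entries giving no number at all, so the series offers no measured step in this assay on which a direction could be read.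

Compound 4 `CC(C)(C)OC(=O)Nc1ncc(C(Oc2ccc3cc(Br)ccc3c2)c2ccc(Cl)cc2)s1` differs from compound 3 in a single place (6-bromonaphthalen-2-yl in place of 4-isopropyl-2-methylphenyl on an oxygen on a saturated carbon), that is, 6-bromonaphthalen-2-yl in place of 4-isopropyl-2-methylphenyl on an oxygen on a saturated carbon. Among the compounds with values here, no step between measured compounds exists to set a size for this change. The expectation for the step in this assay is therefore none beyond the usual scatter, with a step that the limit leaves unreadable from compound 3 to compound 4 as the estimated movement from compound 3 to compound 4. Compound 4 is expected to give 60000 nM in this assay, within a range of 20000 nM to 200000 nM, and most likely again to be reported only as a limit.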

Compound 4, half-maximal cytotoxic concentration: > 50000 nM
Compound 4: a limit, no number; the forecaster's own chance of this, stated with the estimate: 70%; the middle value does not contradict the limit.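

Compound 3 and compound 4 are both reported only as limits in this assay, so the exchange of 4-isopropyl-2-methylphenyl for 6-bromonaphthalen-2-yl gives no readable step: the limit of > 50000 nM in this assay, at which 2 of the 4 values shown sit.

The compounds shown leave open what actual figure any of them would give in this assay, and whether this exchange moves that figure at all.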